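A few compounds are considered here, and "the series" means these few. Any claim that something is new, unique, unknown or untested is made for them only; others in the source may bear on it.

Compound 1, `O=C(Nc1cccc(C(=O)O)c1)N[C@H]1CC[C@H](Oc2ccc(F)cc2)CC1`: in a functional assay on CRL2813 cells (Homo sapiens) for cytotoxicity, read by sulforhodamine B assay, with a stated time of 5 days (a lower number here means a stronger inhibitor, a higher number a weaker inhibitor), compound 1 gives > 20000 nM, a limit of the assay.
Compound 2, `O=C(Nc1ccccc1I)N[C@H]1CC[C@H](Oc2ccc(F)cc2)CC1`: in this assay compound 2 gives > 20000 nM, again a limit.
Compound 3, `O=C(Nc1ccc(F)cc1)N[C@H]1CC[C@H](Oc2ccc(F)cc2)CC1`: in this assay compound 3 gives 20000 nM.

Compound 3 therefore holds the only number shown, the other two values being limits, as the limit of > 20000 nM in this assay, at which 2 of the 3 values shown sit, records. The step to compound 4, `CSc1cccc(NC(=O)N[C@H]2CC[C@H](Oc3ccc(F)cc3)CC2)c1`, is 3-(methylsulfanyl)phenyl in place of 4-fluorophenyl on an amide-type nitrogen. Going by the values given here, the related steps of a number no higher from compound 1 to compound 3 (the limit leaves the size open) and a number no higher from compound 2 to compound 3 (the limit leaves the size open) both change the same aryl group, yet neither has a readable size, so no measured step tells how far compound 4 may move in this assay. With nothing pointing either way, compound 4 is expected to stay close to compound 3, and its estimate is 20000 nM (range 8000 nM to 40000 nM). The expected step is thus no change at the digits printed from compound 3 to compound 4 (within the scatter), within the scatter.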

Compound 4, half-maximal inhibitory concentration: 11100 nM
Beside the measured number, compound 4's estimate is 1.8-fold (0.26 log units) above it; the range from low to high includes it.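

Going by these compounds alone, this is the first step at this place, on the amide-type nitrogen, with a readable size in this assay: a 1.8-fold lower number from compound 3 to compound 4 (0.26 log units; within the scatter), so 3-(methylsulfanyl)phenyl and 4-fluorophenyl cannot be told apart here. The other two new steps, an at least 1.8-fold lower number from compound 2 to compound 4 (0.25 log units; that floor lies within the scatter) and an at least 1.8-fold lower number from compound 1 to compound 4 (0.25 log units; that floor lies within the scatter), give only floors, and neither floor leaves the scatter. Part of the series still gives no exact number: the limit of > 20000 nM in this assay, at which 2 of the 4 values shown sit.

On these data alone, whether an amine or a longer chain in place of methylsulfanyl would move the number beyond the scatter remains open. The steps among compound 1, compound 2 and compound 3 cannot be read.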